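Methoxy substitution in a thiosemicarbazone series against prostate cells

A few compounds are considered here, and "the series" means these few. Any claim that something is new, unique, unknown or untested is made for them only; others in the source may bear on it.

Compound 1 `CC1=CC[C@H](C(C)(C)NC(=S)N/N=C/c2ccccc2)CC1` and compound 2 `COc1ccc(/C=N/NC(=S)NC(C)(C)[C@H]2CC=C(C)CC2)cc1` share one core and differ only by methoxy in place of hydrogen on an aromatic carbon. In a functional assay on PC-3 cells (Homo sapiens) for inhibition, read by sulforhodamine B assay, with a stated time of 48 h (on this read-out lower numbers stand for stronger inhibition of growth and higher numbers for weaker inhibition of growth), compound 1 gives 1300 nM. For compound 2 the value in this assay is a limit of the assay, < 40 nM, the point described by the limit of < 40 nM in this assay, at which 1 of the 3 values shown sits. The resulting step, an at least 32-fold lower number from compound 1 to compound 2 (1.51 log units; beyond the scatter), can thus only be stated as a minimum. Compound 3 `CC1=CC[C@H](C(C)(C)NC(=S)N/N=C(\C)c2ccccc2)CC1` rests on a different core; the difference between the two cores is not broken down here. In this assay compound 3 also reaches only a limit of the assay, > 100000 nM, the point described by the limit of > 100000 nM in this assay, at which 1 of the 3 values shown sits. For the measured compounds named here, compound 4 `COc1ccc(/C(C)=N/NC(=S)NC(C)(C)[C@H]2CC=C(C)CC2)cc1` has not yet been measured; it differs from compound 3 by methoxy in place of hydrogen on an aromatic carbon, the same change at the same place as the one made between compound 1 and compound 2. For compound 4 the step is expected to be an at least 3.3-fold lower number from compound 3 to compound 4 (0.52 log units; beyond the scatter), an expectation resting on an at least 32-fold lower number from compound 1 to compound 2 (1.51 log units; beyond the scatter), although a start at a limit leaves its true size open. Compound 4 is therefore estimated at 30000 nM, with a likely range from 3000 nM to 300000 nM.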

Compound 4, concentration for 50% growth inhibition: 83600 nM
The estimate for compound 4 lay 2.8-fold (0.45 log units) below the measured number; measured number inside the range.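

In this assay, putting methoxy in place of hydrogen on the core of compound 3 gives an at least 1.1-fold lower number from compound 3 to compound 4 (0.07 log units; that floor lies within the scatter), so on this core the smallest step the data allow cannot be told apart from the usual scatter of repeated measurements. Going by these compounds, compound 3 stands at a limit of the assay, > 100000 nM, so the true size of this step stays open and it could be small or much larger. Set side by side, the two steps show that the large gain on the first core cannot simply be assumed on the second, but they do not show that the change acts differently on the two cores: the same change on two cores in this assay, an at least 32-fold lower number (1.51 log units; beyond the scatter) from compound 1 to compound 2 and an at least 1.1-fold lower number (0.07 log units; that floor lies within the scatter) from compound 3 to compound 4; the limit leaves it open whether they differ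

The compounds shown leave open whether a different group at this place on the aromatic ring, such as a hydroxyl, an ethoxy or a dimethylamino group, would follow methoxy on either core. Compound 2 is also at a limit of the assay, < 40 nM, which leaves the full size of the step on the first core open as well.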